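Replacing the Side Group of Compound 1

The source may hold more compounds than are shown below. What is called first, only, known or untested is meant among the compounds shown, and "the series" means these compounds.

Within the data shown here, in a functional assay on HCT-116 cells (Homo sapiens) for inhibition, read by CCK-8 assay, with a stated time of 48 h (a higher number here means a weaker inhibitor, a lower number a stronger inhibitor), compound 1 `COc1ccc(CN(C(=O)CSc2nc3ccccc3o2)c2cc(OC)c(OC)c(OC)c2)cc1` gives 3280 nM, the lower of the two numbers measured so far. Compound 2 `COc1ccc(CN(C(=O)CSC(=S)N2CCc3ccccc3C2)c2cc(OC)c(OC)c(OC)c2)cc1` gives 15900 nM. Unmeasured compound 3 `CCN1CCN(CC(=O)N(Cc2ccc(OC)cc2)c2cc(OC)c(OC)c(OC)c2)CC1` differs from compound 1 as follows: 4-ethylpiperazin-1-yl in place of (1,3-benzoxazol-2-yl)sulfanyl on a saturated chain carbon bound to a carbonyl carbon. Among the measured compounds shown here, compound 2 offers the only guide, because its group exchange is a modest step: a 4.8-fold higher number from compound 1 to compound 2 (0.69 log units; beyond the scatter). That exchange is not the same one, so a single step gives weak support. A higher number in this assay is expected, with the estimated step being a 3.0-fold higher number from compound 1 to compound 3 (0.48 log units; beyond the scatter). Compound 3 is estimated at 10000 nM, with an expected range of 3000 nM to 35000 nM.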

Compound 3, half-maximal inhibitory concentration: > 20000 nM
Compound 3: no number, only a limit; the forecaster's own chance of this, stated with the estimate: 15%; middle value at least 2.0-fold (0.30 log units) away from the limit.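

In this assay, compound 3 reaches only a limit of the assay, > 20000 nM. Putting 4-ethylpiperazin-1-yl in place of (1,3-benzoxazol-2-yl)sulfanyl gives an at least 6.0-fold higher number from compound 1 to compound 3 (0.78 log units; beyond the scatter), so this saturated chain carbon does not tolerate every exchange of its group. The true size of the step stays unknown, because the reading is capped: the limit of > 20000 nM in this assay, at which 1 of the 3 values shown sits.

The compounds shown leave open how a small amine such as dimethylamino, or a longer chain carrying the (1,3-benzoxazol-2-yl)sulfanyl group, would read here. They also leave open whether any replacement can give a lower number.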